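Swapping the amine arm of a quinoline-linked pyrrole

A few compounds are considered here, and "the series" means these few. Any claim that something is new, unique, unknown or untested is made for them only; others in the source may bear on it.

The compounds here share a core that carries a chlorinated bicyclic aromatic part joined through a hydrazine-type link to a five-membered ring bearing an amine-substituted side arm. They were tested in an ADME assay on WEHI13 cells (Mus musculus) for cytotoxicity, read by MTT assay; a lower number here means a stronger inhibitor, a higher number a weaker inhibitor. Compound 1 `Cc1c(CN2CCCC2)cc(-c2ccc(Cl)cc2)n1Nc1ccnc2cc(Cl)ccc12` gives 2060 nM. Among the measured compounds shown here, compound 2 `CCN(CC)Cc1cc(-c2ccccc2)n(Nc2ccnc3cc(Cl)ccc23)c1C` gives 4380 nM; of the two numbers known, compound 2 stands at the higher one, and the gap to compound 1 is beyond the usual scatter, so compound 2 is the weaker inhibitor of the pair. Compound 3 `CCN(CC)Cc1cc(C)n(Nc2ccnc3cc(Cl)ccc23)c1C` was run in this assay, and for compound 3 the entry reads "not determined" (no result reported), so no result was reported for it.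

Compound 4 `Cc1c(CNC[C@@H]2CCCN3CCCC[C@H]23)cc(-c2ccccc2)n1Nc1ccnc2cc(Cl)ccc12` differs from compound 2 in one place: a group of 12 heavy atoms (10 carbon, 2 nitrogen; 2 six-membered non-aromatic rings with 1 hetero atom each) in place of a group of 5 heavy atoms (4 carbon, 1 nitrogen; no ring), on a saturated chain carbon bound to an aromatic carbon. This exchange puts a much larger, bicyclic group on the side arm, while the rest of the molecule stays as in compound 2. For the measured compounds named here, no measured pair of compounds shows what such a swap does here, so the expectation rests on compound 2 alone. The step from compound 2 to compound 4 is expected to be small, at most a modest move toward a lower number, a 1.5-fold lower number from compound 2 to compound 4 (0.16 log units; within the scatter). Compound 4 is therefore estimated at 3000 nM in this assay, with a range from 1000 nM to 9000 nM.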

Compound 4, half-maximal inhibitory concentration: 7440 nM
Compound 4: middle estimate off by 2.5-fold (0.39 log units), on the low side, within the range that was stated.
By their numbers in this assay, from the lowest: compound 1; then compounds 2 and 4 (each within the scatter of the next).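

In this assay, putting the much larger group in place of diethylamino, on a saturated chain carbon bound to an aromatic carbon, gives a 1.7-fold higher number from compound 2 to compound 4 (0.23 log units; within the scatter), and this step lies within the usual scatter. The numbers of the two compounds therefore cannot be told apart, so at this place the side arm can carry two six-membered non-aromatic rings, two defined stereocentres and a hydrogen-bond donor without a difference that this measurement can resolve. No measured information on these compounds explains this outcome.

This is a single step from a single starting compound, so it cannot show whether the same exchange would give a similar result on a different core, or whether the two defined stereocentres of compound 4 matter to its number. It also leaves open what a much smaller dimethylamino group or a carboxylic acid would do at the same place, and only such compounds, each differing from compound 2 in this one place, could show how far the tolerance seen here extends.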